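Swapping the Aryl Group on the Amide Nitrogen

The source may report more compounds than this note shows. Statements on the series, on what has been measured and on what is new or still open speak of the compounds shown alone.

Two measured compounds share one core and differ only in the aryl group on an amide-type nitrogen. Compound 1 `O=C(/C=C/C(=O)N1C/C(=C\c2ccccc2)C(=O)/C(=C/c2ccccc2)C1)Nc1ccc([N+](=O)[O-])cc1` carries 4-nitrophenyl and gives 40000 nM in a functional assay on CCRF-CEM cells (Homo sapiens) for cytotoxicity; on this read-out higher numbers stand for weaker inhibition and lower numbers for stronger inhibition. Compound 2 `Cc1cccc(C)c1NC(=O)/C=C/C(=O)N1C/C(=C\c2ccccc2)C(=O)/C(=C/c2ccccc2)C1` carries 2,6-dimethylphenyl and gives 7400 nM, the lower of the two numbers; the step of a 5.4-fold lower number from compound 1 to compound 2 (0.73 log units; beyond the scatter). Compound 3 `CC(=O)c1ccc(NC(=O)/C=C/C(=O)N2C/C(=C\c3ccccc3)C(=O)/C(=C/c3ccccc3)C2)cc1` makes the change (4-acetylphenyl in place of 2,6-dimethylphenyl on an amide-type nitrogen). Among the measured compounds shown here, only that one step bears on this, and it shows the 2,6-dimethylphenyl group going with the lower number, so removing it again is expected to partly undo that gain: for compound 3 a modest rise is expected, a 2.7-fold higher number from compound 2 to compound 3 (0.43 log units; beyond the scatter). Compound 3 is therefore estimated at 20000 nM, within 7000 nM to 60000 nM.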

Compound 3, half-maximal inhibitory concentration: 1700 nM
For compound 3 the middle estimate is 12-fold (1.07 log units) above the measured one; the measured number lies below the stated range.
By their numbers in this assay, from the lowest: compound 3; then compound 2; then compound 1.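

Putting 4-acetylphenyl in place of 2,6-dimethylphenyl on the amide-type nitrogen gives a 4.4-fold lower number from compound 2 to compound 3 (0.64 log units; beyond the scatter) in this assay, so the two methyl groups are not needed for a low number here. Acetyl in place of nitro on the aromatic carbon gives a 24-fold lower number from compound 1 to compound 3 (1.37 log units; beyond the scatter) and is the largest step so far, so the choice of this one group alone spans the lowest and highest numbers shown. From the compounds shown here alone, whether an amine, a carboxylic acid or a longer chain on that aromatic carbon would lower the number further stays open. Nothing measured here says why these groups differ.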